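The compounds below may be only part of what the source reports. "The series", "measured", "known", "first", "only" and "open" are said of these compounds alone.

Compound 1, `CCCCN(CC)c1cc(C)nc2c1NC(=O)CN2c1ccc(Br)cc1Br`, in an assay on HEK-293T cells for displacement of a labelled ligand from corticotropin-releasing factor receptor 1 (Homo sapiens), read by scintillation counting, with a stated time of 2 h; on this read-out lower numbers stand for stronger inhibition and higher numbers for weaker inhibition: 1.3 nM
Compound 2, `CCCCN(CC)c1cc(C)nc2c1NC(=O)CN2c1ccc(Br)cc1C`, in this assay: 4.4 nM
Compound 3, `CCCCN(CC)c1cc(C)nc2c1NC(=O)CN2c1ccc(Br)cc1CC`, in this assay: 2.5 nM

All three compounds share the same core and differ only in the ring attached to the ring nitrogen. Compound 3 has the second highest of the three numbers, but its neighbours lie close: the step of a 1.8-fold lower number from compound 2 to compound 3 (0.25 log units; within the scatter) and the step of a 1.9-fold higher number from compound 1 to compound 3 (0.28 log units; within the scatter) are both too small to separate the compounds with confidence.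

Compound 4, `CCCCN(CC)c1cc(C)nc2c1NC(=O)CN2c1ccc(Cl)cc1Cl`, has not been measured. It differs from compound 3 by 2,4-dichlorophenyl in place of 4-bromo-2-ethylphenyl on a nitrogen on an aromatic ring in a ring. Among the measured compounds shown here, two measured steps bear on this change. The step of a 1.9-fold higher number from compound 1 to compound 3 (0.28 log units; within the scatter) shows that ethyl in place of bromo made little difference, and the step of a 3.4-fold higher number from compound 1 to compound 2 (0.53 log units; beyond the scatter) shows that methyl in place of bromo gave a modestly higher number. Compound 4 carries two halogens again, as compound 1 does, so a small step downward, staying within the scatter, is expected: a 1.4-fold lower number from compound 3 to compound 4 (0.14 log units; within the scatter). Compound 4 is therefore estimated at 1.8 nM, with a range from 0.7 nM to 5 nM.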

Compound 4, inhibition constant: 3.4 nM
Estimate against measurement, compound 4: 1.9-fold (0.28 log units) below; low and high end bracket the measured number.
By their numbers in this assay, from the lowest: compounds 1, 3, 4 and 2 (each within the scatter of the next, the first and the last beyond it).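

With 2,4-dichlorophenyl in place of 2,4-dibromophenyl on the ring nitrogen, a 2.6-fold higher number from compound 1 to compound 4 (0.42 log units; beyond the scatter) shows that two halogens on this ring do not by themselves match compound 1, and that the kind of halogen counts here. Against the rings that carry a methyl or ethyl group, 2,4-dichlorophenyl cannot be told apart: a 1.4-fold higher number from compound 3 to compound 4 (0.13 log units; within the scatter) and a 1.3-fold lower number from compound 2 to compound 4 (0.11 log units; within the scatter) are both within the scatter. Nothing available explains the step between the two dihalogenated rings.

From the compounds shown here alone, both halogens change at once in that step, so which of them carries it stays open; a 4-bromo-2-chlorophenyl ring would separate the two. Going by these compounds, how a methoxy group or an amine on this ring would read in this assay is also open.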